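Swapping a Methylsulfonyl for an Amino Group

The source may report more compounds than this note shows. Statements on the series, on what has been measured and on what is new or still open speak of the compounds shown alone.

Compound 1, `CS(=O)(=O)c1cncc(-c2ccc3ncc(-c4ccc(S(=O)(=O)C5CC5)cc4)n3n2)c1`, gives < 5000 nM in a physicochemical assay for solubility, at pH 2 (a higher number here means a more soluble compound, a lower number a less soluble compound), which is a limit of the assay.
Compound 2, `CS(=O)(=O)c1cccc(-c2ccc3ncc(-c4cncc(S(C)(=O)=O)c4)n3n2)c1`, gives 16000 nM in this assay.
Compound 3, `CS(=O)(=O)c1ccc(-c2cnc3ccc(-c4cncc(S(C)(=O)=O)c4)nn23)cc1`, gives < 5000 nM in this assay, again a limit rather than a number.

Among the measured compounds shown here, compound 3 therefore sits at the limit of < 5000 nM in this assay, at which 2 of the 3 values shown sit, together with compound 1, and the one measured step that reaches it, a step that the two limits leave unreadable from compound 1 to compound 3, cannot be sized. Compound 4, `CS(=O)(=O)c1ccc(-c2cnc3ccc(-c4cncc(N)c4)nn23)cc1`, differs from compound 3 by amino in place of methylsulfonyl on an aromatic carbon. For the measured compounds named here, no measured step touches this position, so the only guide is that compound 3 starts at the floor of the assay. The step of an at least 6.0-fold higher number from compound 3 to compound 4 (0.77 log units; beyond the scatter) is an estimate of a rise beyond the usual scatter. Compound 4 is expected to give about 30000 nM, within 5000 nM to 200000 nM.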

Compound 4, solubility: 174000 nM
Compound 4: middle estimate off by 5.8-fold (0.76 log units), on the low side, within the range that was stated.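

In this assay, amino in place of methylsulfonyl on this aromatic carbon gives a large, readable step: an at least 34-fold higher number from compound 3 to compound 4 (1.54 log units; beyond the scatter). Among the compounds shown here, the earlier compounds offered no readable step at all, and none at this position, so this is the only sized change here. The true size stays open because compound 3 gives only a limit: the limit of < 5000 nM in this assay, at which 2 of the 4 values shown sit.

From the compounds shown here alone, whether this size belongs to the amino group itself remains open, since a methylamino group, a hydroxyl or a carboxylic acid on the same carbon could give a similar result. Also open, going by these compounds, is whether the same swap would act alike on the other methylsulfonyl-bearing ring.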